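The source may hold more compounds than are shown below. What is called first, only, known or untested is meant among the compounds shown, and "the series" means these compounds.

Series notes. In an assay on LtK cells with ATP-sensitive inward rectifier potassium channel 11 (Homo sapiens) as the target (on this read-out higher numbers stand for an effect only at larger amounts of compound and lower numbers for an effect already at smaller amounts), compound 1 `CCCC(=O)Nc1c(C(O)(C(F)(F)F)C(F)(F)F)ccc2ccccc12` gives 131 nM. Among the measured compounds shown here, compound 2 `CC(C)=CC(=O)Nc1c(C(O)(C(F)(F)F)C(F)(F)F)ccc2ccccc12` gives 46 nM in this assay and holds the lowest of the two numbers, with a 2.8-fold lower number from compound 1 to compound 2 (0.45 log units; beyond the scatter) as the only measured step. Compound 3 `CC(C)CCC(=O)Nc1c(C(O)(C(F)(F)F)C(F)(F)F)ccc2ccccc12` is not yet measured; it differs from compound 2 by isopentyl in place of 2-methylprop-1-en-1-yl on a carbonyl carbon. For the measured compounds named here, the single step on hand concerns the same carbonyl position but a different pair of groups, and the isopentyl of compound 3 is closer in kind to the propyl of compound 1 than to the 2-methylprop-1-en-1-yl of compound 2. For compound 3 a modest rise is therefore expected, a 2.0-fold higher number from compound 2 to compound 3 (0.29 log units; within the scatter). Compound 3 is estimated at 90 nM, range 35 nM to 250 nM.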

Compound 3, half-maximal effective concentration: 49 nM
For compound 3 the middle estimate is 1.8-fold (0.26 log units) above the measured one; the range from low to high includes it.
By their numbers in this assay, from the lowest: compounds 2 and 3 (each within the scatter of the next); then compound 1.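

Working from the carbonyl carbon, the double bond of the 2-methylprop-1-en-1-yl is not needed to hold the number, since the saturated isopentyl stays within the scatter (a 1.1-fold higher number from compound 2 to compound 3 (0.03 log units; within the scatter)). Among these saturated chains, isopropyl in place of methyl on a saturated chain carbon, two bonds along the chain from a carbonyl carbon, accounts for a step beyond the scatter (a 2.7-fold lower number from compound 1 to compound 3 (0.43 log units; beyond the scatter)). Nothing on hand explains either step.

Still open, as far as these compounds go, is whether a longer chain, a cyclohexyl ring or a terminal amine or carboxylic acid would be tolerated at this carbonyl carbon. Also open, from the compounds shown here alone, is how a straight chain of the same length as isopentyl compares with the branched one.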